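This account rests on a few compounds, and the source may have more. Where it says the series, first, only, none or still open, it means among the compounds named here.

Working notes, antiproliferative series.

Among the compounds with values here, compound 1 `CCN(CC)CCNc1cc(C)c2cc(NC(=O)c3ccc(Cl)c(Cl)c3)ccc2n1` stands lowest of the three numbers so far: in a functional assay on MCF7 cells (Homo sapiens) for antiproliferative activity, read by MTT assay, with a stated time of 72 h (on this read-out lower numbers stand for stronger inhibition and higher numbers for weaker inhibition), compound 1 gives 1420 nM. Compound 2 `CCc1ccc(C(=O)Nc2ccc3nc(N4CCN(CC)CC4)cc(C)c3c2)cc1` gives 3060 nM in this assay, and compound 3 `CCN1CCN(c2cc(C)c3cc(NC(=O)c4cccnc4)ccc3n2)CC1` gives 26600 nM. Compound 1 and compound 2 differ in two places, so their values are only compared, not read as one step. Within the data shown here, the single one-place step known, an 8.7-fold higher number from compound 2 to compound 3 (0.94 log units; beyond the scatter), sits on the carbonyl side of the core.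

Compound 4 `Cc1cc(N2CCCCC2)nc2ccc(NC(=O)c3ccc(Cl)c(Cl)c3)cc12` is the next to be measured in this assay. Relative to compound 1 the change is piperidin-1-yl in place of (2-(diethylamino)ethyl)amino on an aromatic carbon. Among the measured compounds shown here, no measured step touches this aromatic carbon, so the only guide is that the one known step, an 8.7-fold higher number from compound 2 to compound 3 (0.94 log units; beyond the scatter), was modest and on a different part of the molecule. A step of similar or smaller size is expected, with direction uncertain, a higher number held slightly more likely. The expectation for compound 4 is 2500 nM, within 800 nM to 8000 nM, which means a step of a 1.8-fold higher number from compound 1 to compound 4 (0.25 log units; within the scatter) is expected.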

Compound 4, half-maximal inhibitory concentration: 31100 nM
The estimate for compound 4 lay 12-fold (1.09 log units) below the measured number; the whole stated range lies below it.
By their numbers in this assay, from the lowest: compound 1; then compound 2; then compounds 3 and 4 (each within the scatter of the next).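

Piperidin-1-yl in place of (2-(diethylamino)ethyl)amino on the aromatic carbon next to the ring nitrogen gives a 22-fold higher number from compound 1 to compound 4 (1.34 log units; beyond the scatter) in this assay, so this position is not a silent one while the carbonyl side stays fixed. Within the data shown here, a change here moves the number at least as far as the only earlier step, on the carbonyl side, an 8.7-fold higher number from compound 2 to compound 3 (0.94 log units; beyond the scatter). No measurement on hand explains the rise.

Among these compounds, the single step changes several things at once: the amino hydrogen-bond donor, the second nitrogen and the open chain all leave together, and their shares cannot be separated. A piperidine carrying a diethylaminoethyl group, or a (2-(diethylamino)ethyl)oxy chain in place of the amino link, would help to separate them.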